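This account rests on a few compounds, and the source may have more. Where it says the series, first, only, none or still open, it means among the compounds named here.

Measured in a functional assay on A549 cells (Homo sapiens) for antiproliferative activity, read by MTT assay, with a stated time of 72 h; on this read-out higher numbers stand for weaker inhibition and lower numbers for stronger inhibition:
Compound 1, `COc1cc(C(=O)c2sc3ccccc3c2-c2ccc(Cl)cc2)cc(OC)c1OC`, gives 7500 nM.
Compound 2, `COc1cc(C(=O)c2sc3ccccc3c2-c2ccc(C)cc2)cc(OC)c1OC`, gives 7800 nM.
Compound 3, `COc1cc(C(=O)c2sc3ccccc3c2Nc2ccc(Cl)cc2)cc(OC)c1OC`, gives 3100 nM.

Compound 4, `COc1cc(C(=O)c2sc3ccccc3c2Nc2ccc(C)cc2)cc(OC)c1OC`, has not yet been measured. It stands to compound 3 as compound 2 stands to compound 1. Between the first two, the change methyl in place of chloro on an aromatic carbon gave a 1.0-fold higher number from compound 1 to compound 2 (0.02 log units; within the scatter). Between compound 3 and compound 4 the change is methyl in place of chloro on an aromatic carbon, at a place described in the same words, so it is the same change. The shared core of compound 3 and compound 4 differs from that of compound 1 by (4-chlorophenyl)amino in place of 4-chlorophenyl on an aromatic carbon, a change that gave a 2.4-fold lower number from compound 1 to compound 3 (0.38 log units; beyond the scatter) and a 2.5-fold lower number from compound 2 to compound 3 (0.40 log units; beyond the scatter). Since the earlier change did not move the number in a 1.0-fold higher number from compound 1 to compound 2 (0.02 log units; within the scatter), the expected step is a 1.0-fold higher number from compound 3 to compound 4 (0.01 log units; within the scatter). Compound 4 is therefore estimated at 3200 nM, most likely between 1800 nM and 6000 nM.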

Compound 4, half-maximal inhibitory concentration: 2600 nM
For compound 4 the middle estimate is 1.2-fold (0.09 log units) above the measured one; low and high end bracket the measured number.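

In this assay, methyl in place of chloro gives a 1.2-fold lower number from compound 3 to compound 4 (0.08 log units; within the scatter), and this agrees with the same change on the other core: the same change on two cores in this assay, a 1.0-fold higher number (0.02 log units; within the scatter) from compound 1 to compound 2 and a 1.2-fold lower number (0.08 log units; within the scatter) from compound 3 to compound 4, 1.2-fold (0.09 log units) apart, within the scatter of two such steps

Replacing the directly attached aryl group with an arylamino group still lowers the number when methyl is present, giving a 3.0-fold lower number from compound 2 to compound 4 (0.48 log units; beyond the scatter) and a 2.9-fold lower number from compound 1 to compound 4 (0.46 log units; beyond the scatter). This shows that the swap between chloro and methyl makes no measurable difference on these two cores in this one assay, but two cores cannot show that the same holds across the whole series.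

The compounds shown leave open whether a methoxy group, a fluoro group or a carboxylic acid in the place of chloro and methyl would also leave the number unchanged.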